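Triazole substituent change and fibroblast cytotoxicity

This account rests on a few compounds, and the source may have more. Where it says the series, first, only, none or still open, it means among the compounds named here.

Measured so far:
compound 1, `O=C1O[C@H]([C@@H](O)Cn2cc(-c3cc(C(F)(F)F)cc(C(F)(F)F)c3)nn2)C(OCc2ccccc2)=C1OCc1ccccc1`: 80700 nM
compound 2, `COc1ccc(-c2cn(C/C=C3\OC(=O)C(OCc4ccccc4)=C3OCc3ccccc3)nn2)cc1`: > 100000 nM
compound 3, `CC(C)(C)c1cn(C[C@H](O)[C@H]2OC(=O)C(OCc3ccccc3)=C2OCc2ccccc2)nn1`: 13300 nM

All three compounds were tested in an ADME assay on HFF cells (Homo sapiens) for cytotoxicity, read by MTT assay, with a stated time of 72 h; a lower number here means a stronger inhibitor, a higher number a weaker inhibitor. Compound 3 gives 13300 nM, the lowest of the two numbers obtained, with compound 1 the nearest at a clearly higher value, a gap that lies beyond the scatter. For compound 2 the assay reports no number but only a limit, > 100000 nM, which is the limit described as the limit of > 100000 nM in this assay, at which 1 of the 3 values shown sits.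

Compound 4, `O=C1O[C@H]([C@@H](O)Cn2cc(CCO)nn2)C(OCc2ccccc2)=C1OCc1ccccc1`, has not yet been measured. Compared with compound 3 it differs in one place: 2-hydroxyethyl in place of tert-butyl on an aromatic carbon. Within the data shown here, no comparable change between two measured compounds is available, so no measured step can guide the expectation. With that caveat, compound 4 is expected to give a higher number than compound 3 in this assay, by a step estimated as a 3.8-fold higher number from compound 3 to compound 4 (0.58 log units; beyond the scatter), though a result within the scatter or even only a limit is also possible. The estimate for compound 4 is 50000 nM, within a range from 15000 nM to 150000 nM.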

Compound 4, half-maximal inhibitory concentration: 58500 nM
Compound 4: the middle estimate sits 1.2-fold (0.07 log units) below what was measured, and the stated range covers the measured number.
By their numbers in this assay, from the lowest: compound 3; then compounds 4 and 1 (each within the scatter of the next). At a limit, above all of these: compound 2.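

In this assay, among these compounds, this pair gives the first measured step at this position, a 4.4-fold higher number from compound 3 to compound 4 (0.64 log units; beyond the scatter) with 2-hydroxyethyl in place of tert-butyl on an aromatic carbon and the rest of the structure unchanged. Among the compounds shown here, the number therefore responds to the group at this carbon alone, whereas the earlier compounds differed from one another in more than one place. Compound 4 and compound 1 now lie within the scatter of each other, which leaves compound 3 apart from both, and no measurement shown offers a reason for the step.

One pair cannot separate the effect of removing tert-butyl from that of adding the hydroxyl. As far as these compounds go, how an ethyl group, a longer chain or an amine on this carbon would read in this assay also remains open.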